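From a furan to a substituted phenyl on the hydrazone carbon

The source may hold more compounds than are shown below. What is called first, only, known or untested is meant among the compounds shown, and "the series" means these compounds.

Compound 3 `O=C(N/N=C/c1ccco1)c1cccc(S(=O)(=O)N2CCOCC2)c1` is one of three analogues built on the shared core. In a functional assay on EC9706 cells (Homo sapiens) for antiproliferative activity, read by MTT assay, with a stated time of 72 h (a lower number here means a stronger inhibitor, a higher number a weaker inhibitor), compound 3 gives only a limit, > 100000 nM. Compound 1 `C/C(=N\NC(=O)c1cccc(S(=O)(=O)N2CCOCC2)c1)c1cccc(N)c1` likewise reaches only a limit in this assay, > 100000 nM. Compound 2 `C/C(=N\NC(=O)c1cccc(S(=O)(=O)N2CCOCC2)c1)c1ccc(O)cc1` gives 71400 nM in this assay, and the step of an at least 1.4-fold lower number from compound 1 to compound 2 (0.14 log units; that floor lies within the scatter) remains within the scatter. Two of the three values thus sit at the limit of > 100000 nM in this assay, at which 2 of the 3 values shown sit. Compound 4 `CCOc1cccc(/C=N/NC(=O)c2cccc(S(=O)(=O)N3CCOCC3)c2)c1O` differs from compound 3 in one place: 3-ethoxy-2-hydroxyphenyl in place of furan-2-yl on a carbon with a double bond to nitrogen. Among the compounds with values here, no measured step exchanges these two groups, so compound 3 supplies only a ceiling and no direction. The step of an at least 1.2-fold lower number from compound 3 to compound 4 (0.09 log units; that floor lies within the scatter) is therefore only an expectation of continued weakness. Compound 4 is estimated at 80000 nM, within 25000 nM to 250000 nM.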

Compound 4, half-maximal inhibitory concentration: 15400 nM
Compound 4: the middle estimate sits 5.2-fold (0.72 log units) above what was measured; measured number outside the range, below it.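

On the carbon with a double bond to nitrogen, 3-ethoxy-2-hydroxyphenyl in place of furan-2-yl gives an at least 6.4-fold lower number from compound 3 to compound 4 (0.81 log units; beyond the scatter) in this assay. This is the only step shown that lies beyond the scatter, so a change at this place can move the read-out. Its size remains a floor, since compound 3 stands at a limit: the limit of > 100000 nM in this assay, at which 2 of the 4 values shown sit.

The change replaces the ring and adds the hydroxyl and ethoxy groups together, so the compounds shown do not separate their contributions. A plain phenyl, a 2-hydroxyphenyl or a longer propoxy chain in place of ethoxy would bear on that question.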